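The compounds below may be only part of what the source reports. "The series", "measured", "known", "first", "only" and "open" are said of these compounds alone.

Measured compounds in a functional assay on Ehrlich cells (Mus musculus) for cytotoxicity, read by MTT assay, with a stated time of 48 h; on this read-out lower numbers stand for stronger inhibition and higher numbers for weaker inhibition:
- compound 1, `Cc1ccc(OCC(=O)NNC(=O)c2cc3ccccc3oc2=O)c(C(=O)c2ccccc2Br)c1`, gives 8000 nM
- compound 2, `Cc1ccc(OCC(=O)NNC(=O)c2cc3ccccc3oc2=O)c(C(=O)c2ccc(Cl)cc2)c1`, gives 56600 nM

Among the compounds with values here, compound 2 holds the highest of the two numbers in this assay; its nearest neighbour is compound 1, and the single measured step of a 7.1-fold higher number from compound 1 to compound 2 (0.85 log units; beyond the scatter) separates them. Compound 3, `Cc1ccc(OCC(=O)NNC(=O)c2cc3ccccc3oc2=O)c(C(=O)c2cccc(Br)c2)c1`, is not yet measured. It differs from compound 2 by 3-bromophenyl in place of 4-chlorophenyl on a carbonyl carbon.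

Within the data shown here, only the step from compound 1 to compound 2 bears on this change, and it covers a different pair of phenyl groups: bromine leaves and chlorine enters there, whereas from compound 2 to compound 3 bromine enters as 3-bromophenyl. Among the measured compounds shown here, no measured pair shows 3-bromophenyl against any other group, so the direction is uncertain; the size of a 7.1-fold higher number from compound 1 to compound 2 (0.85 log units; beyond the scatter) suggests a change of at most similar extent. Compound 3 is expected near 20000 nM, in the range 6000 nM to 60000 nM, a step of a 2.8-fold lower number from compound 2 to compound 3 (0.45 log units; beyond the scatter) that is estimated, not measured.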

Compound 3, half-maximal inhibitory concentration: 66400 nM
Compound 3: the middle estimate sits 3.3-fold (0.52 log units) below what was measured; measured number outside the range, above it.
By their numbers in this assay, from the lowest: compound 1; then compounds 2 and 3 (each within the scatter of the next).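

In this assay, 3-bromophenyl in place of 4-chlorophenyl on the carbonyl carbon gives a 1.2-fold higher number from compound 2 to compound 3 (0.07 log units; within the scatter), so this change does not separate the two compounds. With bromine retained, 3-bromophenyl in place of 2-bromophenyl gives an 8.3-fold higher number from compound 1 to compound 3 (0.92 log units; beyond the scatter), which shows that two bromophenyl groups on this carbonyl carbon need not read alike and leaves compound 1 alone at the low end of the three. No supporting measurement is available to explain either step.

Going by these compounds, it remains open whether the lower number of compound 1 depends on bromine itself or would also appear with another group in the same place. A plain phenyl or a methoxyphenyl group on this carbonyl carbon would give the series a reference for reading these steps.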